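The source may report more compounds than this note shows. Statements on the series, on what has been measured and on what is new or still open speak of the compounds shown alone.

Measured compounds:
compound 1, `CC(=O)NC1CCCN(S(=O)(=O)c2ccc(F)cc2)C1`, 1 mg/kg
compound 2, `CCC(=O)N1CCCC(NS(=O)(=O)c2ccc(F)cc2)C1`, 10 mg/kg
compound 3, `O=S(=O)(NCC1CCN(S(=O)(=O)c2ccc(F)cc2)CC1)c1ccc(F)cc1`, 1 mg/kg

The three measured compounds were examined in a functional assay on the whole organism with Mus musculus as the target, with a stated time of 30 min; on this read-out higher numbers stand for an effect only at larger amounts of compound and lower numbers for an effect already at smaller amounts. In this assay compound 1 gives 1 mg/kg, and compound 3 gives 1 mg/kg; the two numbers are level at the digits shown and together they are the lowest of the three. Compound 2, in which the acyl group sits on the ring nitrogen and the sulfonamide on the ring carbon, gives 10 mg/kg, a higher number that lies beyond the usual scatter.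

The next compound, compound 4, `CC(=O)NCC1CCCN(S(=O)(=O)c2ccc(F)cc2)C1`, has not yet been measured in this assay. Compared with compound 1 it carries acetamidomethyl in place of acetamido on a saturated ring carbon. For the measured compounds named here, no step between two measured compounds follows exactly this change, but compound 3, which likewise places a methylene between the ring and the nitrogen of its substituent, gives 1 mg/kg, the same number as compound 1. On that basis no shift beyond the scatter is expected, and the step of a 1.5-fold higher number from compound 1 to compound 4 (0.18 log units; within the scatter) is estimated to be small. Compound 4 is therefore expected to give about 1.5 mg/kg, with a range from 0.5 mg/kg to 5 mg/kg.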

Compound 4, minimum effective dose: 10 mg/kg
The estimate for compound 4 lay 6.7-fold (0.82 log units) below the measured number; measured number above the stated range.
By their numbers in this assay, from the lowest: compounds 1 and 3 (each within the scatter of the next); then compounds 2 and 4 (each within the scatter of the next).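

In this assay, for the compounds shown here, acetamidomethyl in place of acetamido on a saturated ring carbon gives a 10-fold higher number from compound 1 to compound 4 (1.00 log units; beyond the scatter), the first step in this set that can be read at a single place, and it lies beyond the scatter. The two groups match in hydrogen-bond donors, hydrogen-bond acceptors, double bonds outside aromatic rings and net charge, and neither carries a ring, so the computed comparison leaves the added methylene as the difference, and this small change at a position two ring bonds from the ring nitrogen is enough to require a larger dose. No measurement shown here gives a reason for this step.

This single pair cannot say whether a still longer chain, such as acetamidoethyl, would move the number further in the same direction, or whether the step would recur on a different core. Nor do the compounds shown tell how a free amine, a carboxylic acid or a simple hydroxymethyl at this ring carbon would compare with acetamido.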